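Benzimidazole halogen exchange from compound 2 to compound 3

A few compounds are considered here, and "the series" means these few. Any claim that something is new, unique, unknown or untested is made for them only; others in the source may bear on it.

Among the measured compounds shown here, compound 1 `CN1CCN(CCCN(c2nc3cc(Cl)c(Cl)cc3[nH]2)[C@@H]2CC[C@]3(c4cccc(C#N)c4)C[C@@H]3C2)CC1` and compound 2 `CN1CCN(CCCN(c2nc3cc(Cl)c(Cl)cc3[nH]2)[C@@H]2CC[C@]3(c4cccc(C#N)c4)C[C@H]23)CC1` share the same core and side chains and differ only in how the small ring of that core is fused; no single-point step between them is tabulated, so only their numbers are compared. In a functional assay on the whole organism for inhibition, with Mus musculus as the target, with a stated time of 24 h, at a dose of 30 mg/kg by the oral route (on this read-out lower numbers stand for less inhibition and higher numbers for more inhibition at the one dose given (going by the name of the read-out)), compound 1 gives 97%, whereas compound 2 gives 51%, the lowest of the two numbers and lower than compound 1 by more than the usual scatter.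

Compound 3 `CN1CCN(CCCN(c2nc3cc(F)c(F)cc3[nH]2)[C@@H]2CC[C@]3(c4cccc(C#N)c4)C[C@H]23)CC1` carries 5,6-difluoro-1H-benzimidazol-2-yl in place of 5,6-dichloro-1H-benzimidazol-2-yl on an amine nitrogen. For the measured compounds named here, no measured pair isolates that exchange, so its effect on the whole-animal read-out is not anchored by data. A modest downward step, or none beyond the scatter, is expected a number 11 percentage points lower from compound 2 to compound 3 (beyond the scatter). In this assay compound 3 is estimated at 40%, with a range from 15% to 65%.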

Compound 3, a percentage reported as inhibition, in the whole organism at one dose (the size of the read-out at that dose, not a potency): 33%
The estimate for compound 3 lay 7 percentage points above the measured number; low and high end bracket the measured number.
By their numbers in this assay, from the lowest: compound 3; then compound 2; then compound 1.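

In this assay, the 5,6-difluoro-1H-benzimidazol-2-yl in place of 5,6-dichloro-1H-benzimidazol-2-yl on an amine nitrogen gives a number 18 percentage points lower from compound 2 to compound 3 (beyond the scatter). Among the compounds shown here, this is the only single-place step so far, and it shows that the read-out at this dose is sensitive to which halogen pair this group carries, with the dichloro group ahead on the core of compound 2. No available evidence bears on the reason for this step.

Still open, going by these compounds, is whether the same exchange on the core of compound 1 gives a step of similar size, since this one step comes from a single core. Also open, on these data alone, is where 5,6-dibromo, 5,6-dimethyl or unsubstituted benzimidazol-2-yl groups on the same amine nitrogen would stand relative to the dichloro and difluoro groups.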